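The compounds below may be only part of what the source reports. "The series", "measured", "known", "first", "only" and "open" are said of these compounds alone.

In an assay for inhibition of serine/threonine-protein kinase PAK 4 (Homo sapiens), read by FRET and Z'-LYTE, with a stated time of 60 min, tested at 5 uM, in the presence of a further agent that is not named here (on this read-out lower numbers stand for a weaker effect and higher numbers for a stronger effect at the one concentration tested), compound 1 `CCCCCOC(=O)N1CCN(C(=O)c2nc(Nc3cc(C4CC4)[nH]n3)c3cc(Cl)ccc3n2)C[C@H]1C` gives 12.6%, compound 2 `C[C@@H]1CN(C(=O)c2nc(Nc3cc(C4CC4)[nH]n3)c3cc(Cl)ccc3n2)CCN1C(=O)OCC(Cl)(Cl)Cl` gives 63%, and compound 3 `C[C@@H]1CN(C(=O)c2nc(Nc3cc(C4CC4)[nH]n3)c3cc(Cl)ccc3n2)CCN1C(=O)OCOC(=O)C(C)(C)C` gives 24.1%. Compound 3 thus stands second highest of the three, lying a number 11.5 percentage points higher from compound 1 to compound 3 (beyond the scatter) and a number 38.9 percentage points lower from compound 2 to compound 3 (beyond the scatter). Compound 4 `CC(OC(=O)N1CCN(C(=O)c2nc(Nc3cc(C4CC4)[nH]n3)c3cc(Cl)ccc3n2)C[C@H]1C)OC(=O)C(C)(C)C` differs from compound 3 by methyl in place of hydrogen on a saturated chain carbon bound to two oxygens next to a carbonyl group. Within the data shown here, none of the measured steps touches this carbon: each of them exchanges the whole group on the carbon bound to one oxygen next to the carbonyl, as in a number 50.4 percentage points higher from compound 1 to compound 2 (beyond the scatter), and so they speak only to that larger exchange. Among the measured compounds shown here, with no step bearing on the change itself, the expectation for compound 4 is a step of a number 0.9 percentage points higher from compound 3 to compound 4 (within the scatter), that is, nothing beyond the scatter. Compound 4 is therefore estimated at 25%, with a range from 10% to 45%.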

Compound 4, a percentage reported as inhibition, at one concentration (the size of the read-out at that concentration, not a potency): 23.6%
Estimate against measurement, compound 4: 1.4 percentage points above; the measured number falls inside the stated range.
By their numbers in this assay, from the lowest: compound 1; then compounds 4 and 3 (each within the scatter of the next); then compound 2.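

In this assay, among these compounds, methyl in place of hydrogen on a saturated chain carbon bound to two oxygens next to a carbonyl group brings a number 0.5 percentage points lower from compound 3 to compound 4 (within the scatter) and so this carbon, untouched by the earlier steps, takes the methyl with no change beyond the scatter. The wider gaps remain, with a number 39.4 percentage points lower from compound 2 to compound 4 (beyond the scatter) and a number 11 percentage points higher from compound 1 to compound 4 (beyond the scatter) on the same side as those of compound 3. Nothing measured here explains this result.

Going by these compounds, whether an ethyl group or a phenyl ring on this carbon would leave the read-out equally unmoved stays open. So does the effect of an amine in place of the tert-butyl group.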